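This account rests on a few compounds, and the source may have more. Where it says the series, first, only, none or still open, it means among the compounds named here.

Of the compounds shown here, three have been tested so far in an ADME assay on HEL cells (Homo sapiens) for cytotoxicity, with a stated time of 3 days (a higher number here means that more compound is tolerated, a lower number that less compound is tolerated), and all three sit at the tolerant end of what the test can report. Compound 1 `CCC1(Cc2ccccc2)OS(=O)(=O)C=C1OCc1ccc(F)cc1` gives in this assay only a limit, > 50000 nM, which means the test reached its ceiling without finding a number. Compound 2 `CCC1(Cc2ccccc2)OS(=O)(=O)CC1=O` gives in this assay 200000 nM. Compound 3 `CC1(C(c2ccccc2)c2ccccc2)OS(=O)(=O)C=C1OCc1ccccc1` gives in this assay 200000 nM. Where compound 1 stands is therefore known only as a limit: the limit of > 50000 nM in this assay, at which 1 of the 3 values shown sits.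

The next compound in line is compound 4 `CCC1(Cc2ccccc2)OS(=O)(=O)C=C1OCc1ccc([N+](=O)[O-])cc1`. It differs from compound 1 in one place: nitro in place of fluoro on an aromatic carbon. For the measured compounds named here, no pair of measured compounds differing in a single place is available, so there is no measured step to lean on. Because all three measured compounds, including compound 1 at > 50000 nM, are tolerated at high concentration, the expectation is that compound 4 will also be well tolerated, with any step from compound 1 staying within the usual scatter rather than moving in a clear direction. The expected step is a step that the limit leaves unreadable from compound 1 to compound 4. For compound 4 in this assay the estimate is 150000 nM, within a range from 50000 nM to 400000 nM.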

Compound 4, half-maximal cytotoxic concentration: < 200000 nM
Compound 4 was reported as a limit; the forecaster's own chance of this, stated with the estimate: 40%; the middle value is on the limit's open side.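

Compound 1 and compound 4 are both reported in this assay only as limits and not as numbers, so the step between these two compounds cannot be read. The compounds shown leave open whether nitro in place of fluoro on an aromatic carbon changes how much compound is tolerated in this assay, and in which direction.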